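Ethoxy for methyl on the aryl group of compound 3

The source may report more compounds than this note shows. Statements on the series, on what has been measured and on what is new or still open speak of the compounds shown alone.

In a functional assay on HL-60 cells (Homo sapiens) for antiproliferative activity, read by MTT assay, with a stated time of 72 h (a higher number here means a weaker inhibitor, a lower number a stronger inhibitor), compound 1 (`CCOc1ccc(-c2sc(NC)nc2-c2cc(OC)c(OC)c(OC)c2)cc1`) gives 1.8 nM. Compound 2 (`COc1cc(-c2nc(N(C)C)sc2-c2ccc3ccccc3c2)cc(OC)c1OC`) gives 2570 nM, and compound 3 (`COc1cc(-c2nc(N(C)C)sc2-c2ccc(C)cc2)cc(OC)c1OC`) gives 3480 nM. Compound 3 therefore stands level with compound 2 within the scatter, and both numbers are far higher than that of compound 1.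

The next compound is compound 4 (`CCOc1ccc(-c2sc(N(C)C)nc2-c2cc(OC)c(OC)c(OC)c2)cc1`), which has ethoxy in place of methyl on an aromatic carbon of compound 3, turning 4-methylphenyl into 4-ethoxyphenyl: ethoxy in place of methyl on an aromatic carbon.

Within the data shown here, only one measured step concerns this aryl position: a 1.4-fold higher number from compound 2 to compound 3 (0.13 log units; within the scatter), with 4-methylphenyl in place of naphthalen-2-yl. Taken alone, it suggests that a change here may do little. Against that, compound 1 is the only measured compound carrying 4-ethoxyphenyl, and it gives 1.8 nM. Among the measured compounds shown here, compound 1 is not otherwise identical to compound 4, however, and no measured step isolates the change from methyl to ethoxy.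

The two indications are weighed together, so a real move towards a lower number is expected, though well short of the value of compound 1. The expected size is a 12-fold lower number from compound 3 to compound 4 (1.06 log units; beyond the scatter), and this estimate is uncertain.

For compound 4 the estimated value in this assay is 300 nM, with an expected range of 20 nM to 3500 nM.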

Compound 4, half-maximal inhibitory concentration: 303 nM
The estimate for compound 4 lay 1.0-fold (0.00 log units) below the measured number, within the range that was stated.
By their numbers in this assay, from the lowest: compound 1; then compound 4; then compounds 2 and 3 (each within the scatter of the next).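

In this assay, among these compounds, this position proves responsive: ethoxy in place of methyl gives an 11-fold lower number from compound 3 to compound 4 (1.06 log units; beyond the scatter), and 4-ethoxyphenyl in place of naphthalen-2-yl gives an 8.5-fold lower number from compound 2 to compound 4 (0.93 log units; beyond the scatter), whereas the only earlier step here, a 1.4-fold higher number from compound 2 to compound 3 (0.13 log units; within the scatter), showed no separation between its two aryl groups. With 4-ethoxyphenyl held constant, the change at the nitrogen still gives a 170-fold higher number from compound 1 to compound 4 (2.23 log units; beyond the scatter), so the aryl change alone leaves compound 4 far from compound 1, and the nitrogen substitution emerges as a second, separate point of sensitivity in this small set. No measurement shown here gives a reason for either step.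

Going by these compounds, it remains open whether the gain from ethoxy depends on its oxygen or on its chain length; a methoxy, propoxy or propyl group at this position would help separate the two. Also open, on these data alone, is whether the methyl-to-ethoxy step keeps its size when the nitrogen carries hydrogen, as in compound 1, and how a larger nitrogen substituent such as ethylamino would compare.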